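Tail exchange on the chain of compound 3

A few compounds are considered here, and "the series" means these few. Any claim that something is new, unique, unknown or untested is made for them only; others in the source may bear on it.

Compound 1 `Nc1ncnc2c1c(-c1ccc3cc[nH]c3c1)cn2-c1ccc(OCCNCCO)cc1`: 220 nM
Compound 2 `NCc1ccc(-n2cc(-c3ccc4cc[nH]c4c3)c(C(F)(F)F)n2)cc1`: 30 nM
Compound 3 `NCCCCn1cc(-c2ccc3cc[nH]c3c2)c(C(F)(F)F)n1`: 330 nM

In an assay on isolated protein for inhibition of Myeloperoxidase (Homo sapiens) (on this read-out higher numbers stand for weaker inhibition and lower numbers for stronger inhibition), compound 3 gives the highest of the three numbers; compound 1 lies within the scatter of it, whereas compound 2 sits lower by a margin beyond the scatter. Within the data shown here, the one measured step is an 11-fold higher number from compound 2 to compound 3 (1.04 log units; beyond the scatter), a large one. Compound 4 `NC(=O)CCn1cc(-c2ccc3cc[nH]c3c2)c(C(F)(F)F)n1` carries carbamoyl in place of 2-aminoethyl on a saturated chain carbon, two bonds along the chain from an aromatic nitrogen. Among the measured compounds shown here, that measured step exchanges the whole group on the aromatic nitrogen and does not cover the replacement of the terminal amine by an amide; no measured pair bears directly on this change. The step of a 1.5-fold higher number from compound 3 to compound 4 (0.18 log units; within the scatter) is therefore expected to be modest, with no direction claimed beyond the scatter. Compound 4 is estimated at 500 nM, with a range from 150 nM to 1700 nM.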

Compound 4, half-maximal inhibitory concentration: 4200 nM
Estimate against measurement, compound 4: 8.4-fold (0.92 log units) below; measured number above the stated range.
By their numbers in this assay, from the lowest: compound 2; then compounds 1 and 3 (each within the scatter of the next); then compound 4.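

Carbamoyl in place of 2-aminoethyl gives a 13-fold higher number from compound 3 to compound 4 (1.10 log units; beyond the scatter) on the same chain, so the terminal group alone moves the number, not only exchange of the whole group on the aromatic nitrogen. The entering and leaving groups have the same counts of heavy atoms, donors and acceptors, so those counts do not separate compound 3 from compound 4. Against the aryl group, a 140-fold higher number from compound 2 to compound 4 (2.15 log units; beyond the scatter) marks 2-carbamoylethyl in place of 4-(aminomethyl)phenyl as a large change.

Nothing available explains the change at this position. Open, going by these compounds, is how a carboxylic acid or a longer chain ending in an amine would read here.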